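The source may report more compounds than this note shows. Statements on the series, on what has been measured and on what is new or still open speak of the compounds shown alone.

Measured compounds:
- compound 1 `COc1ncnc2c1c(-c1ccoc1)cn2[C@@H]1O[C@H](CO)[C@@H](O)[C@H]1O`: 1790 nM
- compound 2 `CSc1ncnc2c1c(-c1ccoc1)cn2[C@@H]1O[C@H](CO)[C@@H](O)[C@H]1O`: 5390 nM

Among the compounds with values here, in a functional assay on HeLa S3 cells (Homo sapiens) for antiproliferative activity, read by XTT assay, with a stated time of 72 h (on this read-out higher numbers stand for weaker inhibition and lower numbers for stronger inhibition), compound 1 has the lowest of the two numbers; the only other measured compound is compound 2, reached by a 3.0-fold higher number from compound 1 to compound 2 (0.48 log units; beyond the scatter), the change being methylsulfanyl in place of methoxy on an aromatic carbon.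

Compound 3 `COc1ncnc2c1c(I)cn2[C@@H]1O[C@H](CO)[C@@H](O)[C@H]1O` differs from compound 1 by iodo in place of furan-3-yl on an aromatic carbon. Within the data shown here, the one measured step, a 3.0-fold higher number from compound 1 to compound 2 (0.48 log units; beyond the scatter), concerns the methoxy group and not the carbon that is changed here, so no measured step bears on this change, and the expectation rests on the structural change alone. Removing the five-membered aromatic ring in favour of a single heavy atom is expected to give a step of a 4.5-fold higher number from compound 1 to compound 3 (0.65 log units; beyond the scatter) toward a higher number, with wide uncertainty. For compound 3 the estimate in this assay is 8000 nM, expected to lie between 1500 nM and 40000 nM.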

Compound 3, half-maximal inhibitory concentration: 14300 nM
Beside the measured number, compound 3's estimate is 1.8-fold (0.25 log units) below it; the range from low to high includes it.
By their numbers in this assay, from the lowest: compound 1; then compound 2; then compound 3.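

In this assay, the carbon two ring bonds from the ring nitrogen proves sensitive to substitution: with the methoxy group held constant, replacing furan-3-yl with iodo gives an 8.0-fold higher number from compound 1 to compound 3 (0.90 log units; beyond the scatter). Within the data shown here, this is the first measured change at this carbon, and it shows that iodo does not stand in for furan-3-yl here without a loss of antiproliferative activity. The step swaps a five-membered aromatic ring with one hydrogen-bond acceptor for a single iodine atom, so it cannot assign the loss to any one of these differences, and no measurement on hand explains it.

As far as these compounds go, whether a thiophen-3-yl or phenyl ring at this carbon would retain the number of compound 1 remains open. So does whether the iodo-for-furan-3-yl step carries over when methylsulfanyl replaces methoxy.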